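Legumain series: switching the warhead on compound 2

A few compounds are considered here, and "the series" means these few. Any claim that something is new, unique, unknown or untested is made for them only; others in the source may bear on it.

Going by the values given here, compound 2 `CCOC(=O)/C=C/C(=O)N(CC(N)=O)NC(=O)[C@@H]1CCCN1C(=O)C1(NC(C)=O)CC1` gives 9.3 nM in an assay on isolated protein for inhibition of legumain (Mus musculus), read by fluorescence, with stated times of 30 s and 2.5 h (on this read-out lower numbers stand for stronger inhibition and higher numbers for weaker inhibition), the lowest of the three numbers measured so far. Compound 1 `CCOC(=O)/C=C/C(=O)N(CC(N)=O)NC(=O)[C@@H]1CCCN1C(=O)[C@H]1CSCN1C(C)=O` gives 167 nM and compound 3 `CCOC(=O)/C=C/C(=O)N(CC(N)=O)NC(=O)[C@@H]1CCCN1C(=O)C(NC(C)=O)=C(C)C` gives 148 nM in this assay. The measured steps all concern the acyl group on the proline nitrogen: an 18-fold lower number from compound 1 to compound 2 (1.25 log units; beyond the scatter), a 16-fold higher number from compound 2 to compound 3 (1.20 log units; beyond the scatter), and a 1.1-fold lower number from compound 1 to compound 3 (0.05 log units; within the scatter).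

Compound 4 `CCOC(=O)C1OC1C(=O)N(CC(N)=O)NC(=O)[C@@H]1CCCN1C(=O)C1(NC(C)=O)CC1` keeps the cyclopropyl acyl group of compound 2 and instead changes the other end of the molecule: a group of 8 heavy atoms (5 carbon, 3 oxygen; one three-membered non-aromatic ring with 1 hetero atom) in place of a group of 7 heavy atoms (5 carbon, 2 oxygen; no ring), on a carbonyl carbon. Among the compounds with values here, no measured step touches this position, so the three steps above give no direct guidance on its size; they only show that the rest of the scaffold tolerates variation at one site by large margins while leaving this end untouched. The expectation for compound 4 is therefore uncertain, with a modest loss of potency relative to compound 2 taken as the central case, a step of a 2.7-fold higher number from compound 2 to compound 4 (0.43 log units; beyond the scatter). Compound 4 is estimated at 25 nM in this assay, within a range of 5 nM to 150 nM.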

Compound 4, half-maximal inhibitory concentration: 4.4 nM
For compound 4 the middle estimate is 5.7-fold (0.75 log units) above the measured one; measured number outside the range, below it.
By their numbers in this assay, from the lowest: compound 4; then compound 2; then compounds 3 and 1 (each within the scatter of the next).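

In this assay, going by these compounds alone, putting the group with a three-membered non-aromatic ring with 1 hetero atom in place of 2-(ethoxycarbonyl)ethenyl, on a carbonyl carbon whose other neighbours are an amide-type nitrogen, gives a 2.1-fold lower number from compound 2 to compound 4 (0.33 log units; beyond the scatter), the first measured step at this end of the molecule. The 2-(ethoxycarbonyl)ethenyl group and its second double bond are therefore not needed for a low number here, at least with the cyclopropyl acyl group in place, though this rests on a single pair. No available data explain the direction or size of this step.

As far as these compounds go, whether the same change holds with the acyl groups of compound 1 and compound 3 remains open. So does the effect of a carboxylic acid or a longer alkyl chain in place of the ethoxycarbonyl part.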